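Benzyloxy ring substituent swap in an oxadiazinone series

The source may hold more compounds than are shown below. What is called first, only, known or untested is meant among the compounds shown, and "the series" means these compounds.

Measured compounds:
Compound 1 `N#CCCCn1nc(-c2ccc(OCc3ccccc3)cc2)oc1=O` — 410 nM
Compound 2 `CC(C#N)n1nc(-c2ccc(OCc3ccccc3)cc2)oc1=O` — 48000 nM
Compound 3 `COc1cccc(COc2ccc(C3=NN(CCC#N)C(=O)CO3)cc2)c1` — 68 nM

Of the compounds shown here, three have been measured in an assay for inhibition of Amine oxidase [flavin-containing] B (Rattus norvegicus); a lower number here means a stronger inhibitor, a higher number a weaker inhibitor. Compound 1 `N#CCCCn1nc(-c2ccc(OCc3ccccc3)cc2)oc1=O` gives 410 nM in this assay, and compound 2 `CC(C#N)n1nc(-c2ccc(OCc3ccccc3)cc2)oc1=O` gives 48000 nM. Among the measured compounds shown here, the only single-point step among them, a 120-fold higher number from compound 1 to compound 2 (2.07 log units; beyond the scatter), concerns the chain on the aromatic nitrogen. Compound 3 `COc1cccc(COc2ccc(C3=NN(CCC#N)C(=O)CO3)cc2)c1` gives 68 nM, the lowest of the three numbers; it differs from compound 1 in more than one place, so the two values can only be set side by side.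

Compound 4 `Cc1ccc(COc2ccc(C3=NN(CCC#N)C(=O)CO3)cc2)cc1` has not yet been measured in this assay. The change from compound 3 to compound 4 is 4-methylphenyl in place of 3-methoxyphenyl on a saturated chain carbon bound to an oxygen on an aromatic ring. For the measured compounds named here, none of the measured steps touches this position, so no measured step bears on it directly, and there is no basis in the data for a direction. Compound 4 is therefore expected to land near compound 3, with the step of a 1.5-fold higher number from compound 3 to compound 4 (0.17 log units; within the scatter) estimated to stay within or close to the scatter. The estimate for compound 4 in this assay is 100 nM, with a range from 25 nM to 400 nM.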

Compound 4, half-maximal inhibitory concentration: 320 nM
Compound 4: middle estimate off by 3.2-fold (0.51 log units), on the low side, and the stated range covers the measured number.
By their numbers in this assay, from the lowest: compound 3; then compounds 4 and 1 (each within the scatter of the next); then compound 2.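

In this assay, putting 4-methylphenyl in place of 3-methoxyphenyl on a saturated chain carbon bound to an oxygen on an aromatic ring gives a 4.7-fold higher number from compound 3 to compound 4 (0.67 log units; beyond the scatter), which shows that this position, untouched by the earlier step, responds to the group it carries. The step is modest beside the large one seen on the chain at the aromatic nitrogen (a 120-fold higher number from compound 1 to compound 2 (2.07 log units; beyond the scatter)), yet it lies beyond the scatter, and it changes both the substituent and its place on the phenyl ring, with a hydrogen-bond acceptor count of 1 in the leaving group and 0 in the entering one. Nothing available here explains the size or direction of this step.

On these data alone, what remains open is whether the substituent or its place on the ring matters more, a question that 3-methylphenyl and 4-methoxyphenyl at this position would separate. Also open, as far as these compounds go, is how an unsubstituted phenyl, or a halogen such as 3-chlorophenyl, would compare on the same core.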